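The source may hold more compounds than are shown below. What is called first, only, known or untested is meant among the compounds shown, and "the series" means these compounds.

Compound 1, `C[C@@H]1CN(c2sc(C3COC3)nc2-c2nc3ccccc3[nH]2)CCN1C(=O)Cn1cnc2cccnc21`, gives 1150 nM.
Compound 2, `COc1ccc(-c2nc(C(F)(F)F)sc2N2CCN(C(=O)Cn3cnc4cccnc43)[C@H](C)C2)cc1`, gives 1190 nM.
Compound 3, `COc1ncc(-c2nc(C(F)(F)F)sc2N2CCN(C(=O)Cn3cnc4cccnc43)[C@H](C)C2)cn1`, gives 158 nM.

These three numbers come from an assay on blood for inhibition of C-X-C chemokine receptor type 3 (Homo sapiens), with a stated time of 30 min; a lower number here means a stronger inhibitor, a higher number a weaker inhibitor. Among them compound 3 stands lowest, and its distance to the other two is beyond the scatter, so it is the strongest inhibitor of the three. The next compound, compound 4, `Cc1ncc(-c2nc(C(F)(F)F)sc2N2CCN(C(=O)Cn3cnc4cccnc43)[C@H](C)C2)cn1`, differs from compound 3 in one place: methyl in place of methoxy on an aromatic carbon.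

For the measured compounds named here, only one measured step touches the same part of the molecule. From compound 2 to compound 3 the aryl group was exchanged, 2-methoxypyrimidin-5-yl in place of 4-methoxyphenyl, and this gave a 7.5-fold lower number from compound 2 to compound 3 (0.88 log units; beyond the scatter). That step altered the ring itself, while the methoxy group stayed in place. Going by the values given here, no measured pair shows what happens when the methoxy group is removed or replaced by methyl, so the step from compound 3 to compound 4 has no direct precedent here. With the ring kept and only a small group exchanged, a change of modest size is expected, more likely toward a higher number than a lower one, and possibly none beyond the scatter.

For compound 4 the expected value in this assay is 320 nM, with a range from 120 nM to 850 nM, which corresponds to an expected step of a 2.0-fold higher number from compound 3 to compound 4 (0.31 log units; beyond the scatter).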

Compound 4, half-maximal inhibitory concentration: 104 nM
The estimate for compound 4 lay 3.1-fold (0.49 log units) above the measured number; the whole stated range lies above it.
By their numbers in this assay, from the lowest: compounds 4 and 3 (each within the scatter of the next); then compounds 1 and 2 (each within the scatter of the next).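

In this assay, replacing methoxy with methyl on the aromatic carbon between two ring nitrogen atoms gives a 1.5-fold lower number from compound 3 to compound 4 (0.18 log units; within the scatter), so compound 3 and compound 4 cannot be told apart here, even though the exchange removes an oxygen atom and a hydrogen-bond acceptor. The lower number seen with the new ring is therefore not tied to methoxy: with 2-methylpyrimidin-5-yl in place of 4-methoxyphenyl, the change is an 11-fold lower number from compound 2 to compound 4 (1.06 log units; beyond the scatter), which shows that this ring can carry either small group and stay well clear of compound 2. No measurement at hand explains why the two groups give such similar numbers.

The compounds shown leave open how much this position accepts beyond methoxy and methyl, since a bare hydrogen, an amine or a longer chain such as ethyl could give a quite different number. They also leave open how much of the step from compound 2 comes from the ring alone, a question that a 4-methylphenyl partner for compound 4 would address directly.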